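The source may hold more compounds than are shown below. What is called first, only, known or untested is meant among the compounds shown, and "the series" means these compounds.

Working notes on the series. The shared core carries a long alkyl amide on one ring carbon and an aryl group on another saturated ring carbon. Compound 1 `CCCCCCCCCCCCCCCCCCNC(=O)[C@@H]1CSC(c2ccc(O)cc2)N1` gives 1600 nM in a functional assay on LNCaP cells (Homo sapiens) for antiproliferative activity, read by sulforhodamine B assay; a lower number here means a stronger inhibitor, a higher number a weaker inhibitor. Compound 2 `CCCCCCCCCCCCCCCCCCNC(=O)[C@@H]1CSC(c2c(OC)cc(OC)cc2OC)N1` gives 2400 nM in this assay. The step of a 1.5-fold higher number from compound 1 to compound 2 (0.18 log units; within the scatter) shows that exchanging the aryl group at this position leaves the number within the scatter. Compound 3 `CCCCCCCCCCCCCCCCCCNC(=O)[C@H]1NC(c2cc(OC)c(OC)c(OC)c2)SC1(C)C` adds two methyl groups on a ring carbon and carries a 3,4,5-trimethoxyphenyl; in this assay compound 3 returns only the limit > 20000 nM. Compound 3 therefore stands at the limit of > 20000 nM in this assay, at which 1 of the 3 values shown sits, with no number that can be set against the rest of the series.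

Compound 4 `CCCCCCCCCCCCCCCCCCNC(=O)[C@H]1NC(c2ccc(N(C)C)cc2)SC1(C)C` keeps the two methyl groups and changes the aryl group only: 4-(dimethylamino)phenyl in place of 3,4,5-trimethoxyphenyl on a saturated ring carbon. Within the data shown here, the one measured step bearing on an aryl exchange at this carbon is a 1.5-fold higher number from compound 1 to compound 2 (0.18 log units; within the scatter), within the scatter, but it was measured without the two methyl groups, and no measured pair isolates those methyl groups. Since compound 3 gives only a limit, the expected step of a number no higher from compound 3 to compound 4 (the limit leaves the size open) is anchored to that limit, with no shift beyond scatter expected from the aryl exchange itself. The estimate for compound 4 in this assay is 20000 nM, in the range 6000 nM to 60000 nM, with a fair chance it again reports only a limit.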

Compound 4, half-maximal inhibitory concentration: > 20000 nM
Compound 4: a limit, no number (the forecaster's own chance of this, stated with the estimate: 55%); the middle value lies on the limit itself.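

In this assay compound 4 gives > 20000 nM as a limit, not a number. Among these compounds, compound 3 also returns only a limit, so no step from compound 3 to compound 4 can be read: the limit of > 20000 nM in this assay, at which 2 of the 4 values shown sit.

Left open is what the two methyl groups contribute on their own, as no pair shown differs by those groups alone.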